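Defluorination step across two cores in cytotoxicity assay

The source may report more compounds than this note shows. Statements on the series, on what has been measured and on what is new or still open speak of the compounds shown alone.

Measured so far:
compound 1 `O=C1O/C(=C\Cn2cc(F)c(=O)[nH]c2=O)C(OCc2ccccc2)=C1OCc1ccccc1`: 5100 nM
compound 2 `O=C1O/C(=C\Cn2ccc(=O)[nH]c2=O)C(OCc2ccccc2)=C1OCc1ccccc1`: 12900 nM
compound 3 `C[C@@]1(CO)O[C@H](c2cc(F)c(N)cc2F)C[C@@H]1O`: > 200000 nM

Compounds 1 and 2 share one core and were tested in an ADME assay on L1210/0 cells (Mus musculus) for cytotoxicity, with a stated time of 48 h; a lower number here means a stronger inhibitor, a higher number a weaker inhibitor; compound 1 gives 5100 nM and compound 2 gives 12900 nM. The change between them is hydrogen in place of fluoro on an aromatic carbon, and it produced a 2.5-fold higher number from compound 1 to compound 2 (0.40 log units; beyond the scatter).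

Compound 3 belongs to a different core; how the two cores differ is not broken down here. For compound 3 this assay gives only a limit, > 200000 nM. This is the limit of > 200000 nM in this assay, at which 1 of the 3 values shown sits.

Compound 4 `C[C@@]1(CO)O[C@H](c2ccc(N)cc2F)C[C@@H]1O` has not been measured in this assay. It differs from compound 3 by hydrogen in place of fluoro on an aromatic carbon. For the measured compounds named here, this is the same kind of change as the one from compound 1 to compound 2, though the surroundings differ: in compound 1 the fluoro sits on a six-membered aromatic ring with 2 nitrogen, ortho to a group of 1 heavy atom, two atoms from the ring nitrogen, meta to a large group and para to a group of 1 heavy atom; in compound 3 it sits on a six-membered aromatic ring of carbon only, ortho to an amino group, meta to a group of 9 heavy atoms and para to a fluoro group.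

Since compound 3 is known only as a limit and the measured step from compound 1 to compound 2 moved the number upward, compound 4 is expected to remain at or beyond the same limit, and the expected step is a step that the limit leaves unreadable from compound 3 to compound 4. The estimate for compound 4 in this assay is 400000 nM, between 150000 nM and 1500000 nM.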

Compound 4, half-maximal inhibitory concentration: > 200000 nM
Compound 4: a limit, no number (the forecaster's own chance of this, stated with the estimate: 90%); the middle value does not contradict the limit.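

In this assay compound 4 gives > 200000 nM, which is a limit and not a number. Compound 3 also stands at a limit, so no step from compound 3 to compound 4 can be read: the limit of > 200000 nM in this assay, at which 2 of the 4 values shown sit.

The compounds shown leave open whether hydrogen in place of fluoro changes the number at all on the core of compound 3.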